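A few compounds are considered here, and "the series" means these few. Any claim that something is new, unique, unknown or untested is made for them only; others in the source may bear on it.

Compound 3 `COc1ccc(CSc2nc3nc(C)cc(Nc4ccc(C(=O)/C=C/c5ccc6ccccc6c5)cc4)n3n2)cc1` gives 250 nM in a functional assay on SW-620 cells (Homo sapiens) for cytotoxicity, read by MTT assay, with stated times of 4 h and 72 h, tested at 5 uM (a lower number here means a stronger inhibitor, a higher number a weaker inhibitor), and stands lowest of the three numbers in hand. Compound 1 `Cc1cc(Nc2ccc(C(=O)/C=C/c3ccc4ccccc4c3)cc2)n2nc(SCc3ccccc3C(F)(F)F)nc2n1` gives 1240 nM and compound 2 `Cc1cc(Nc2ccc(C(=O)/C=C/c3ccc4ccccc4c3)cc2)n2nc(SCc3ccc([N+](=O)[O-])cc3)nc2n1` gives 1130 nM; the step of a 1.1-fold lower number from compound 1 to compound 2 (0.04 log units; within the scatter) sits within the scatter, while a 5.0-fold lower number from compound 1 to compound 3 (0.70 log units; beyond the scatter) and a 4.5-fold lower number from compound 2 to compound 3 (0.66 log units; beyond the scatter) are modest yet beyond it. Compound 4 `Cc1cc(Nc2ccc(C(=O)/C=C/c3ccc4ccccc4c3)cc2)n2nc(SCc3ccc(Cl)cc3)nc2n1` differs from compound 3 by chloro in place of methoxy on an aromatic carbon, on an aromatic carbon of the benzyl ring, para to a large group. The two steps into compound 3 are the only ones that bear on this change: both replacements of methoxy by another group raised the number modestly, and chloro is neither methoxy, nitro nor trifluoromethyl. Compound 4 is therefore expected to lose some ground, near 600 nM with a range of 250 nM to 1500 nM, a step of a 2.4-fold higher number from compound 3 to compound 4 (0.38 log units; beyond the scatter).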

Compound 4, half-maximal inhibitory concentration: 570 nM
Compound 4: middle estimate off by 1.1-fold (0.02 log units), on the high side, within the range that was stated.
By their numbers in this assay, from the lowest: compound 3; then compounds 4, 2 and 1 (each within the scatter of the next, the first and the last beyond it).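

With a 2.3-fold higher number from compound 3 to compound 4 (0.36 log units; beyond the scatter), the 4-methoxybenzyl compound stays apart from a third para substituent, chloro as well as nitro, in this assay. Chloro and nitro are not separated, with a 2.0-fold lower number from compound 2 to compound 4 (0.30 log units; within the scatter), yet a 2.2-fold lower number from compound 1 to compound 4 (0.34 log units; beyond the scatter) is beyond the scatter, a separation from the 2-(trifluoromethyl)phenyl compound that the nitro compound did not show. No measurement here accounts for these steps. Still open, going by these compounds, is whether an amine or a hydroxyl at this place, or a longer chain to the sulfur, would read closer to methoxy or to chloro.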